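The compounds below may be only part of what the source reports. "The series", "measured", "known", "first", "only" and "open" are said of these compounds alone.

Of the compounds shown here, two have so far been measured in an assay on microsomes from brain for inhibition of Fatty-acid amide hydrolase 1 (Rattus norvegicus), read by HPLC, with a stated time of 60 min; on this read-out higher numbers stand for weaker inhibition and lower numbers for stronger inhibition. Compound 1 `O=C(Oc1ccccc1)N1CCC(CCn2ccc3c(F)cccc32)CC1` gives 110 nM, while compound 2 `Cc1ccc2c(ccn2CCC2CCN(C(=O)Oc3ccccc3)CC2)c1` gives 700 nM, the higher of the two numbers by a margin beyond the scatter. Compound 3 `O=C(Oc1ccccc1)N1CCC(CCn2ccc3cc(F)ccc32)CC1` has not yet been measured; it differs from compound 2 by fluoro in place of methyl on an aromatic carbon. Within the data shown here, no step between two measured compounds isolates this change. Since compound 1 also carries a fluoro on its core and gives 110 nM, the number for compound 3 is expected to move downward, as a 2.8-fold lower number from compound 2 to compound 3 (0.45 log units; beyond the scatter). Compound 3 is estimated at 250 nM, within a range from 80 nM to 800 nM.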

Compound 3, half-maximal inhibitory concentration: 130 nM
Compound 3: the middle estimate sits 1.9-fold (0.28 log units) above what was measured; low and high end bracket the measured number.
By their numbers in this assay, from the lowest: compounds 1 and 3 (each within the scatter of the next); then compound 2.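

In this assay the swap of fluoro in place of methyl on this aromatic carbon gives a 5.4-fold lower number from compound 2 to compound 3 (0.73 log units; beyond the scatter) and so shows that this position of the shared core responds to a single-atom change. Compound 3 now stands within the scatter of compound 1, which also carries a fluoro on the core. No measurement at hand accounts for the step. The compounds shown leave open how hydrogen, chloro or methoxy at this position would compare, so it remains unsettled whether methyl raises the number or fluoro lowers it.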